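The compounds below may be only part of what the source reports. "The series", "measured", "known", "first", "only" and "open" are said of these compounds alone.

Measured compounds in an assay for inhibition of 15-hydroxyprostaglandin dehydrogenase [NAD(+)] (Homo sapiens), read by fluorescence, with a stated time of 15 min, in the presence of a further agent that is not named here; a lower number here means a stronger inhibitor, a higher number a weaker inhibitor:
compound 1 `CCCC[S+]([O-])c1sc2nc(-c3nccs3)cc(-c3ccc(CNS(C)(=O)=O)cc3)c2c1N` — 4.6 nM
compound 2 `CCCC[S+]([O-])c1sc2nc(-c3nccs3)cc(-c3ccc(CN)cc3)c2c1N` — 11.5 nM

Going by the values given here, compound 2 holds the highest of the two numbers in this assay ; its only neighbour, compound 1, lies beyond the scatter below it, as the step of a 2.5-fold higher number from compound 1 to compound 2 (0.40 log units; beyond the scatter) shows. Compound 3 `CCCC[S+]([O-])c1sc2nc(-c3nccs3)cc(-c3ccc(CNC(C)=O)cc3)c2c1N` has not yet been measured. Its difference from compound 2 is acetyl in place of hydrogen on an amine nitrogen, giving acetamidomethyl where compound 2 carries aminomethyl. Among the compounds with values here, the one step that bears on this is a 2.5-fold higher number from compound 1 to compound 2 (0.40 log units; beyond the scatter), where removing a methylsulfonyl cap from the same nitrogen raised the number modestly. Putting a different cap back, here acetyl, is expected to bring the number partly back toward compound 1, giving an estimated step of a 1.8-fold lower number from compound 2 to compound 3 (0.25 log units; within the scatter). For compound 3 the expected value in this assay is therefore 6.5 nM, within a range of 3 nM to 14 nM.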

Compound 3, half-maximal inhibitory concentration: 2.5 nM
Beside the measured number, compound 3's estimate is 2.6-fold (0.41 log units) above it; the measured number lies below the stated range.
By their numbers in this assay, from the lowest: compounds 3 and 1 (each within the scatter of the next); then compound 2.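

In this assay, acetyl on the amine nitrogen gives a 4.6-fold lower number from compound 2 to compound 3 (0.66 log units; beyond the scatter), so the lower number is not tied to methylsulfonyl: both capped compounds, compound 1 and compound 3, lie beyond the scatter below the free aminomethyl of compound 2. The two caps themselves cannot be told apart at this position, as a 1.8-fold lower number from compound 1 to compound 3 (0.26 log units; within the scatter) stays within the scatter, even though acetyl and methylsulfonyl are different groups. No measurement at hand explains why capping this nitrogen lowers the number.

On these data alone, whether any substituent on this nitrogen is enough, or a carbonyl or sulfonyl group is needed, remains open, and a plain methyl on the nitrogen would bear on that. As far as these compounds go, how far the cap can grow also remains open, for instance with a benzoyl or a longer acyl chain.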